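A few compounds are considered here, and "the series" means these few. Any claim that something is new, unique, unknown or untested is made for them only; others in the source may bear on it.

Compound 1 `Nc1nc2cc(-c3nn(CCCC(=O)NO)c4ncnc(N)c34)ccc2o1` ends in a hydroxycarbamoyl group on a saturated chain. In a functional assay on HeLa cells (Homo sapiens) for inhibition, read by MTT assay, with a stated time of 72 h (a higher number here means a weaker inhibitor, a lower number a stronger inhibitor), compound 1 gives > 150000 nM, which is a limit of the assay and not a number. Compound 2 `Nc1ncnc2c1c(-c1cnc3[nH]ccc3c1)nn2CCCCC(=O)NO` gives > 150000 nM, also a limit. Compound 3 `Nc1ncnc2c1c(-c1cnc3[nH]ccc3c1)nn2CCCCCC(=O)NO` gives > 150000 nM, again a limit. Every reading so far therefore rests on (the limit of > 150000 nM in this assay, at which 3 of the 3 values shown sit).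

Compound 4 `Nc1nc2cc(-c3nn(CCCCCCCCCC(=O)NO)c4ncnc(N)c34)ccc2o1` keeps the core of compound 1 and changes only the chain: 6-(hydroxycarbamoyl)hexyl in place of hydroxycarbamoyl on a saturated chain carbon, three bonds along the chain from an aromatic nitrogen. In words, 6-(hydroxycarbamoyl)hexyl stands in place of hydroxycarbamoyl on a saturated chain carbon, three bonds along the chain from an aromatic nitrogen.

The nearest measured change also lengthens a chain, though on compounds with a different group on the core: a step that the two limits leave unreadable from compound 2 to compound 3. It offers no size to carry over, so the estimate here is a cautious judgement rather than a transfer of a measured step. The change to compound 4 adds more to the chain than that step did, and only a move towards stronger inhibition could appear as a number in this assay. The expected result, held loosely, is an at least 3.7-fold lower number from compound 1 to compound 4 (0.57 log units; beyond the scatter). Compound 4 may well stop at a limit too. For compound 4 the estimate is 40000 nM, with an expected range of 3000 nM to 150000 nM.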

Compound 4, half-maximal inhibitory concentration: > 50000 nM
Compound 4 was reported as a limit (the forecaster's own chance of this, stated with the estimate: 45%); at least 1.2-fold (0.09 log units) between middle value and limit.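

In this assay compound 4 gives > 50000 nM, which is a limit of the assay and not a number. Compound 1 also stands at a limit, so the step between compound 1 and compound 4 cannot be read. The compounds shown leave open whether 6-(hydroxycarbamoyl)hexyl in place of hydroxycarbamoyl changes inhibition at all, and in which direction.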